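This account rests on a few compounds, and the source may have more. Where it says the series, first, only, none or still open, it means among the compounds named here.

Among the compounds with values here, in a functional assay on OVCAR-4 cells (Homo sapiens) for inhibition (a higher number here means a weaker inhibitor of growth, a lower number a stronger inhibitor of growth), compound 1 `Nc1ccc(-c2nc3cc(F)ccc3s2)cc1` gives 13500 nM and stands highest of the two numbers known so far, while compound 2 `Nc1ccc(-c2nc3ccc(F)cc3s2)cc1Cl` gives 20 nM and lies far lower. Compound 3 `Nc1ccc(-c2nc3cc(F)ccc3s2)cc1Cl` is compound 1 with a single change: chloro in place of hydrogen on an aromatic carbon, ortho to an amino group. Compound 2 also carries a chloro and shows 20 nM as its number, so a large fall beyond the scatter is expected here. The estimated step is a 540-fold lower number from compound 1 to compound 3 (2.73 log units; beyond the scatter) and points towards stronger growth inhibition. Compound 3 is expected near 25 nM with an estimated range from 3 nM to 400 nM for this measurement.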

Compound 3, concentration for 50% growth inhibition: 320 nM
Compound 3: the middle estimate sits 13-fold (1.11 log units) below what was measured; the measured number falls inside the stated range.
By their numbers in this assay, from the lowest: compound 2; then compound 3; then compound 1.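

In this assay, within the data shown here, placing a chloro on the aromatic carbon ortho to an amino group gives a 42-fold lower number from compound 1 to compound 3 (1.63 log units; beyond the scatter), the first step between compounds that differ in one place. It shows that this single added heavy atom, at this position, is enough to change growth inhibition well beyond the scatter. No measurement shown accounts for the size of this step. Open, as far as these compounds go, is whether a methyl, a bromo or a methoxy group at the same position would give a step of similar size, or whether a chloro at another position on that ring would do so.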